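The compounds below may be only part of what the source reports. "The series", "measured", "known", "first", "only" and "open" are said of these compounds alone.

Measured so far in a toxicity assay on NIH3T3 cells (Mus musculus) for cytotoxicity, read by resazurin assay; a lower number here means that less compound is needed, a higher number that more compound is needed for the effect:
Compound 1, `CC(=O)c1ccc(NCc2cncn2Cc2ccc(-c3ccccc3)cc2)cc1-c1ccccc1`, gives > 10000 nM, which is a limit of the assay.
Compound 2, `COC(=O)c1ccc(NCc2cncn2Cc2ccccc2)cc1-c1ccccc1`, gives > 1000 nM, which is a limit of the assay.
Compound 3, `COC(=O)c1ccc(NCc2cncn2Cc2cccc(C)c2)cc1-c1ccccc1`, gives > 10000 nM, which is a limit of the assay.

Within the data shown here, no compound in this small set has a numerical value in this assay. Compound 1 sits at the limit of > 10000 nM in this assay, at which 2 of the 3 values shown sit, shared with compound 3, while compound 2 sits at the limit of > 1000 nM in this assay, at which 1 of the 3 values shown sits. Among the measured compounds shown here, the only step between measured compounds, a step that the two limits leave unreadable from compound 2 to compound 3, is unreadable for that reason, and it concerns a methyl on an aromatic carbon, not the carbonyl carbon.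

Compound 4, `CC(C)OC(=O)c1ccc(NCc2cncn2Cc2ccc(-c3ccccc3)cc2)cc1-c1ccccc1`, is not yet measured. It differs from compound 1 by isopropoxy in place of methyl on a carbonyl carbon. For the measured compounds named here, no measured step touches the carbonyl carbon, so there is nothing among the measured pairs that bears directly on this change. What is available is that compound 1 itself sits at a limit, and that every compound shown so far sits at a limit.

On that basis compound 4 is expected to remain at a limit as well, and the step that the limit leaves unreadable from compound 1 to compound 4 is expected to be nothing beyond the scatter. Compound 4 is estimated at 20000 nM, with a range from 8000 nM to 60000 nM.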

Compound 4, half-maximal effective concentration: > 10000 nM
Compound 4 was reported as a limit; the forecaster's own chance of this, stated with the estimate: 85%; the middle value is on the limit's open side.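

In this assay compound 4 gives > 10000 nM, which is a limit of the assay. Compound 1 also stands at a limit, and no step can be read between compound 1 and compound 4. The compounds shown leave open at what concentration any of them reaches the half-maximal effect, and whether isopropoxy in place of methyl on a carbonyl carbon changes it.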